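This account rests on a few compounds, and the source may have more. Where it says the series, first, only, none or still open, it means among the compounds named here.

Compounds measured in an assay on cell membranes from brain for binding affinity to adenosine receptor A1 (Rattus norvegicus), read by radioligand binding; on this read-out lower numbers stand for stronger inhibition and higher numbers for weaker inhibition:
- compound 1 `CCCCn1cnc2[nH]c(=O)[nH]c(=O)c21` gives 27000 nM
- compound 2 `CC(=O)Cn1c(=O)[nH]c2[nH]c(C3CCCC3)nc2c1=O` gives 2500 nM
- compound 3 `Cn1c(=O)[nH]c2[nH]cnc2c1=O` gives 36000 nM

Compound 3 stands at the highest of the three numbers in this assay. Its nearest neighbour is compound 1, whose number lies within the scatter of that of compound 3, so the two cannot be told apart on these data. Compound 2 lies furthest from compound 3, with a far lower number, well beyond the scatter; compound 2 differs from compound 3 at more than one place, so that gap is not assignable to any single change.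

Compound 4 `C=CCn1c(=O)[nH]c2[nH]cnc2c1=O` has not been measured. Against compound 3 the difference is vinyl in place of hydrogen on a saturated chain carbon bound to an aromatic nitrogen. For the measured compounds named here, no measured pair isolates a change of this kind, so the expected step rests on the change itself and on the spread of the measured numbers. The expectation is a step toward a lower number in this assay, of modest size, probably at or slightly beyond the scatter rather than a large shift. For compound 4 the estimated value is 12000 nM, with a range from 4000 nM to 36000 nM. That estimate means an expected step of a 3.0-fold lower number from compound 3 to compound 4 (0.48 log units; beyond the scatter).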

Compound 4, inhibition constant: 9200 nM
For compound 4 the middle estimate is 1.3-fold (0.12 log units) above the measured one; the range from low to high includes it.
By their numbers in this assay, from the lowest: compound 2; then compound 4; then compounds 1 and 3 (each within the scatter of the next).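

In this assay, the series now has its first comparison that differs in one place only: vinyl in place of hydrogen on a saturated chain carbon bound to an aromatic nitrogen, which can also be read as methyl to allyl, gives a 3.9-fold lower number from compound 3 to compound 4 (0.59 log units; beyond the scatter). This shows that the substituent at this position can move the number beyond the scatter on an otherwise unchanged core, although the step is only modest and rests on a single pair. The compounds shown offer no measured information that explains the step.

Going by these compounds, it remains open whether the step belongs to the double bond or simply to the added carbons, a question that a saturated propyl chain at the same place would help to settle, while a longer butyl chain would show whether the trend continues with length. Also open, on these data alone, is how this position responds to a chain ending in an amine or a carboxylic acid, and whether the step seen here would carry over to a core with other substituents.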